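The source may report more compounds than this note shows. Statements on the series, on what has been measured and on what is new or still open speak of the compounds shown alone.

Measured so far in a functional assay on HSC-2 cells (Homo sapiens) for cytotoxicity; a higher number here means that more compound is tolerated, a lower number that less compound is tolerated:
compound 1, `COc1cc(/C=C2\Cc3ccccc3/C(=C\c3ccc([N+](=O)[O-])cc3)C2=O)ccc1O`: 1450 nM
compound 2, `COc1ccc(/C=C2\Cc3ccccc3/C(=C\c3ccc([N+](=O)[O-])cc3)C2=O)cc1`: 11000 nM

For the measured compounds named here, compound 2 stands highest of the two numbers in this assay; its only neighbour is compound 1, and the one computed step, a 7.6-fold higher number from compound 1 to compound 2 (0.88 log units; beyond the scatter), lies beyond the scatter. Compound 3, `COc1ccc(/C=C2\Cc3ccccc3/C(=C\c3ccc([N+](=O)[O-])cc3)C2=O)cc1OC`, differs from compound 2 by methoxy in place of hydrogen on an aromatic carbon. Going by the values given here, no measured step shows exactly this change. The step from compound 1 to compound 2 bears on it only in part, since it also exchanged a hydroxyl for a methoxy, so its size cannot be read across directly. With the 4-methoxyphenyl of compound 2 retained and only a second methoxy added, a step in this assay of about the scatter, or a small move toward compound 1, is expected. Compound 3 is therefore estimated at 8000 nM (range 3000 nM to 22000 nM), the expected step of a 1.4-fold lower number from compound 2 to compound 3 (0.14 log units; within the scatter) being small.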

Compound 3, half-maximal cytotoxic concentration: 920 nM
The estimate for compound 3 lay 8.7-fold (0.94 log units) above the measured number, and the stated range ends above it.
By their numbers in this assay, from the lowest: compounds 3 and 1 (each within the scatter of the next); then compound 2.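

In this assay, the earlier step from compound 1 to compound 2 changed two things at once, and the new compound separates them. Adding methoxy on the aromatic carbon ortho to the existing methoxy group gives a 12-fold lower number from compound 2 to compound 3 (1.08 log units; beyond the scatter) and is therefore a large change on its own, whereas methyl in place of hydrogen on the oxygen gives a 1.6-fold lower number from compound 1 to compound 3 (0.20 log units; within the scatter) and stays within the scatter. Among these three compounds, then, the difference follows the presence of the oxygen substituent at this position and not the free hydroxyl of compound 1.

Still open, from the compounds shown here alone, is whether an ethoxy, a longer chain, chlorine or an amine at this position would give a number like those of compound 1 and compound 3, and whether the effect holds without the 4-methoxy group. No measurement at hand explains the size of the step.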